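Fluorine removal on the aryl ring of a spiro amide

This account rests on a few compounds, and the source may have more. Where it says the series, first, only, none or still open, it means among the compounds named here.

The series holds three measured amides and one open position. Compound 1 `CC(=O)N1CC2(CC(NC(=O)c3cc(-c4ccc(F)cc4)no3)C2)C1` carries an acetylated spirocyclic amine on the amide side. Compound 2 `CN(C)C(=O)CCNC(=O)c1cc(-c2cccc(F)c2)no1` and compound 3 `CN(C)C(=O)CCNC(=O)c1cc(-c2ccccc2F)no1` instead carry a dimethylamide chain. Among the compounds with values here, in an ADME assay on microsomes from liver (Homo sapiens) for metabolic stability, with a stated time of 0.5 h, tested at 0.5 mg/mL (on this read-out higher numbers stand for a more stable compound and lower numbers for a less stable compound), compound 1 gives 84%, the only plain number in the set. For compound 2 the result is a limit of the assay, > 100%. For compound 3 the result is likewise a limit, > 100%. The step that the two limits leave unreadable from compound 2 to compound 3 is therefore not readable, because of the limit of > 100% in this assay, at which 2 of the 3 values shown sit.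

Compound 4 `CC(=O)N1CC2(CC(NC(=O)c3cc(-c4ccccc4)no3)C2)C1` is the next entry. Its difference from compound 1 is hydrogen in place of fluoro on an aromatic carbon. No measured step in the set touches this change: the one step shown swaps the position of the fluorine rather than removing it, and its size cannot be read. Compound 1 is therefore the only anchor, and with the other two values sitting at a limit there is no basis to expect a shift beyond the scatter in this assay in either direction. Compound 4 is expected to give 85%, within 65% to 100%. The estimated step of a number 1 percentage points higher from compound 1 to compound 4 (within the scatter) thus means no change beyond the scatter, with a fair chance that the assay again reports only a limit.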

Compound 4, percent of the compound remaining in the Homo sapiens assay: > 100%
Compound 4: a limit, no number; the forecaster's own chance of this, stated with the estimate: 30%; at least 15 percentage points between middle value and limit.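

In the Homo sapiens assay, hydrogen in place of fluoro on this aromatic carbon gives a number at least 16 percentage points higher from compound 1 to compound 4 (beyond the scatter), and this step rests on a limit of the assay rather than on a number for the phenyl end. Within the data shown here, it is the first change whose direction can be read, and it shows that the 4-fluorophenyl group is not needed at this position to hold the read-out at the top of the range. In a physicochemical assay for solubility, at pH 6.8 (on this read-out higher numbers stand for higher solubility and lower numbers for lower solubility), compound 1 gives > 100 ug/mL, a limit of the assay, and compound 4 gives > 100 ug/mL, also a limit, so the step on this read-out cannot be read: the limit of > 100 ug/mL in the physicochemical assay, at which 2 of the 2 values shown sit.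

On these data alone, the true size of the gain in the Homo sapiens assay stays open, and the dimethylamide compounds cannot help to fix it: the limit of > 100% in the Homo sapiens assay, at which 3 of the 4 values shown sit. Also open is whether a chloro or a methoxy group on the same aromatic carbon would read like fluoro or like hydrogen, and whether the 4-fluorophenyl to phenyl change would give the same direction with an amine or a longer chain on the amide side.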